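A few compounds are considered here, and "the series" means these few. Any claim that something is new, unique, unknown or untested is made for them only; others in the source may bear on it.

Working notes, this series

Compound 1, `Cc1nc(S(C)(=O)=O)ccc1Oc1ncnc(OC2CCN(C(=S)OC(C)C)CC2)c1F`: in a functional assay on isolated protein for inhibition of Glucose-dependent insulinotropic receptor (Rattus norvegicus), read by HTRF and cAMP accumulation (a higher number here means a larger maximal response, a lower number a smaller maximal response), compound 1 gives 47%.
Compound 2, `Cc1nc(S(C)(=O)=O)ccc1Oc1ncnc(OC2CCN(C(=O)c3noc(C(C)C)n3)CC2)c1F`: in this assay compound 2 gives 81%.

For the measured compounds named here, compound 2 stands highest of the two numbers so far; its only neighbour is compound 1, and the step of a number 34 percentage points higher from compound 1 to compound 2 (beyond the scatter) lies beyond the scatter. That single measured step exchanged the whole group on the amine nitrogen in a ring, a group with no ring for a group carrying a carbonyl and a five-membered aromatic ring, and it was large.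

Compound 3, `Cc1nc(S(C)(=O)=O)ccc1Oc1ncnc(OC2CCN(C(=O)c3ncc(Cl)cn3)CC2)c1F`, is the next point. It differs from compound 2 by 5-chloropyrimidin-2-yl in place of 5-isopropyl-1,2,4-oxadiazol-3-yl on a carbonyl carbon. Going by the values given here, the carbonyl on the amine nitrogen in a ring is kept, so the one measured step bears on it only loosely: it shows that the group on that nitrogen can move the maximal response strongly, but no measured step exchanges one aromatic ring for another on the carbonyl carbon. Among the compounds with values here, with no direct precedent, the expected step of a number 5 percentage points lower from compound 2 to compound 3 (within the scatter) is estimated as none beyond the scatter, with a wide margin. Compound 3 is therefore expected to reach 76% in this assay, estimated between 55% and 97%.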

Compound 3, largest response reached (reported as efficacy), in percent of the reference or control that the assay uses: 77%
Compound 3: middle estimate off by 1 percentage points, on the low side; the measured number falls inside the stated range.
By their numbers in this assay, from the lowest: compound 1; then compounds 3 and 2 (each within the scatter of the next).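

For the compounds shown here, with 5-chloropyrimidin-2-yl in place of 5-isopropyl-1,2,4-oxadiazol-3-yl on a carbonyl carbon, this assay shows a number 4 percentage points lower from compound 2 to compound 3 (within the scatter) and so gives the first direct reading at this position: here, a six-membered aromatic ring with its chlorine and a five-membered aromatic ring with its isopropyl cannot be told apart. The earlier contrast with compound 1 now rests on two groups, since a group carrying 5-chloropyrimidin-2-yl in place of the ringless group on the amine nitrogen in a ring also gives a number 30 percentage points higher from compound 1 to compound 3 (beyond the scatter) and the high maximal response therefore does not belong to the oxadiazole alone. The compounds shown contain no measurement that explains either step.

Because the ring and its substituent change together between compound 2 and compound 3, their separate contributions remain unresolved, and a 5-methoxypyrimidin-2-yl or an unsubstituted pyrimidin-2-yl on the same carbonyl carbon would address that. As far as these compounds go, it also remains open whether an aromatic ring is needed at all, a question that a cyclohexyl group or a simple amine on that carbonyl carbon would test.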